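The compounds below may be only part of what the source reports. "The series", "measured", "known", "first", "only" and "open" are said of these compounds alone.

Measured compounds:
compound 1, `O=C(CCCCCCc1ccccc1)c1ncc(-c2cccc(C(=O)C(F)(F)F)c2)o1`, 16 nM;
compound 2, `O=C(CCCCCCc1ccccc1)c1ncc(-c2ccc(C(=O)C(F)(F)F)cc2)o1`, 65 nM;
compound 3, `Cc1cccc(-c2cnc(C(=O)CCCCCCc3ccccc3)o2)n1`, 3.3 nM.

In an assay (Rattus norvegicus) for inhibition of Fatty-acid amide hydrolase 1 (Homo sapiens) (a lower number here means a stronger inhibitor, a higher number a weaker inhibitor), compound 3 gives the lowest number of the three. Compound 1 gives 16 nM, a number higher by a margin beyond the scatter, and compound 2 gives 65 nM, a number higher still and likewise beyond the scatter. Compound 3 therefore stands as the strongest inhibitor of the three measured in this assay.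

Compound 4, `O=C(CCCCCCc1ccccc1)c1ncc(F)o1`, has not yet been measured in this assay. It differs from compound 3 in one place: fluoro in place of 6-methylpyridin-2-yl on an aromatic carbon. A group of seven heavy atoms that carries one six-membered aromatic ring leaves, and a single fluorine atom enters on the same aromatic carbon of the five-membered ring. For the measured compounds named here, no pair of measured compounds shows a change of this kind, so the size of the step is not known from the data. The account expects that the loss of the 6-methylpyridin-2-yl group weakens inhibition in this assay well beyond the scatter, so that the step of a 61-fold higher number from compound 3 to compound 4 (1.78 log units; beyond the scatter) is estimated to be upward and large. Compound 4 is expected to give about 200 nM in this assay, within a range of 40 nM to 1000 nM.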

Compound 4, inhibition constant: 30 nM
Beside the measured number, compound 4's estimate is 6.7-fold (0.82 log units) above it, outside the stated range (below it).
By their numbers in this assay, from the lowest: compound 3; then compounds 1 and 4 (each within the scatter of the next); then compound 2.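

For the compounds shown here, the replacement of 6-methylpyridin-2-yl by fluoro on this aromatic carbon, next to the ring oxygen, gives a 9.1-fold higher number from compound 3 to compound 4 (0.96 log units; beyond the scatter) in this assay, and this is the first measured size for a change at this place. The six-membered aromatic ring is therefore not needed for inhibition in this assay, since compound 4 gives 30 nM with a single fluorine atom here, although the 6-methylpyridin-2-yl group of compound 3 gives the lower number, 3.3 nM, by a margin beyond the scatter. Compound 4 also lies within the scatter of compound 1, which gives 16 nM while carrying a much larger group on the same carbon, and nothing given here accounts for the size of the step.

From the compounds shown here alone, what a hydrogen atom, a chlorine atom or an unsubstituted pyridin-2-yl ring would give on this carbon stays open, and with it how much of the step belongs to the loss of the ring and how much to the fluorine atom. Also open, going by these compounds, is whether a step of like size would follow with a shorter chain on the carbonyl of the shared core.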